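Amine substituent on the shared core: alkyl to carbonyl

The source may hold more compounds than are shown below. What is called first, only, known or untested is meant among the compounds shown, and "the series" means these compounds.

In an assay on membranes from Urinary bladder (Cricetulus griseus) with Substance-K receptor (Mesocricetus auratus) as the target (on this read-out higher numbers stand for weaker inhibition and lower numbers for stronger inhibition), compound 1, `FC(F)(F)c1ccccc1CN[C@@H]1C2CCN(CC2)[C@@H]1C(c1ccccc1)c1ccccc1`, gives only a limit, >= 100000 nM.
In this assay compound 2, `Clc1ccccc1CCCN[C@@H]1C2CCN(CC2)[C@@H]1C(c1ccccc1)c1ccccc1`, gives likewise only a limit, >= 100000 nM.

The step that the two limits leave unreadable from compound 1 to compound 2 cannot be read, since the limit of >= 100000 nM in this assay, at which 2 of the 2 values shown sit, holds both values. Compound 2 therefore stands at the limit of this assay, with nothing resolved beyond it. Compound 3, `O=C(N[C@@H]1C2CCN(CC2)[C@@H]1C(c1ccccc1)c1ccccc1)c1ccccc1Cl`, differs from compound 2 by (2-chlorophenyl)carbonyl in place of 3-(2-chlorophenyl)propyl on an amine nitrogen. Within the data shown here, no measured step bears on this change; both measured neighbours sit at the limit. Compound 3 is expected to remain near the limit, estimated at 100000 nM with a range from 20000 nM to 500000 nM. The step of a number no higher from compound 2 to compound 3 (the limit leaves the size open) is expected to be none beyond the scatter.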

Compound 3, half-maximal inhibitory concentration: >= 100000 nM
Compound 3: no number, only a limit; the forecaster's own chance of this, stated with the estimate: 80%; the middle value lies on the limit itself.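

Compound 3 adds no readable step against compound 1 or compound 2, as all three sit at one assay limit: the limit of >= 100000 nM in this assay, at which 3 of the 3 values shown sit.

The compounds shown leave open whether any amine substituent on the shared core gives a measurable value in this assay.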